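A few compounds are considered here, and "the series" means these few. Any claim that something is new, unique, unknown or untested is made for them only; others in the source may bear on it.

Compound 1 `COc1nc2ccc(Br)cc2cc1C(c1ccccc1)n1cc(-c2ccc(Br)cc2)nn1`: 10.4%
Compound 2 `CCCCCCCc1cn(C(c2ccccc2)c2cc3cc(Br)ccc3nc2OC)nn1`: 16.6%

In an ADME assay on PANC-1 cells (Homo sapiens) for cytotoxicity, read by sulforhodamine B assay, with a stated time of 48 h, tested at 10 uM (on this read-out higher numbers stand for more inhibition at the one concentration tested (going by the name of the read-out) and lower numbers for less inhibition), compound 2 gives 16.6%. It is one of only two numbers shown, and its single measured step, a number 6.2 percentage points higher from compound 1 to compound 2 (within the scatter), lies within the scatter, so the two compounds cannot be told apart. Compound 3 `CCCCCCc1cn(C(c2ccccc2)c2cc3cc(Br)ccc3nc2OC)nn1` differs from compound 2 by hydrogen in place of methyl on a saturated chain carbon, six bonds along the chain from an aromatic carbon. Going by the values given here, no measured step shortens a chain in this way; the one measured step, a number 6.2 percentage points higher from compound 1 to compound 2 (within the scatter), exchanges a whole group and stays within the scatter, so no movement beyond the scatter is expected in this assay. Compound 3 is therefore estimated at 14%, ranging from 3% to 27%, an expected step of a number 2.6 percentage points lower from compound 2 to compound 3 (within the scatter).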

Compound 3, a percentage reported as inhibition, at one concentration (the size of the read-out at that concentration, not a potency): 6.08%
Beside the measured number, compound 3's estimate is 7.9 percentage points above it; measured number inside the range.
By their numbers in this assay, from the lowest: compounds 3, 1 and 2 (each within the scatter of the next, the first and the last beyond it).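

In this assay, hydrogen in place of methyl on a saturated chain carbon, which turns heptyl into hexyl, gives a number 10.5 percentage points lower from compound 2 to compound 3 (beyond the scatter). Going by these compounds alone, this is the first step here to clear the scatter, so a change of a single carbon can register on this read-out, whereas hexyl in place of 4-bromophenyl gives a number 4.3 percentage points lower from compound 1 to compound 3 (within the scatter) and shows no readable change. Nothing measured explains the drop.

Two chain lengths cannot establish a trend. From the compounds shown here alone, whether a longer chain such as octyl, a shorter one such as butyl, or an amine on the chain would raise or lower the number remains open.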